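The compounds below may be only part of what the source reports. "The series", "measured", "known", "first", "only" and "open" are said of these compounds alone.

Measured compounds in a functional assay on HCT-116 cells (Homo sapiens) for inhibition, read by colorimetric assay, with a stated time of 3 days; on this read-out lower numbers stand for stronger inhibition and higher numbers for weaker inhibition:
Compound 1 `O=C(CCCCCCNC(=O)C(O)(O)C(F)(F)F)Nc1nc(-c2ccccc2)c(-c2ccccc2)s1` gives 29900 nM.
Compound 2 `CC(=O)c1ccc(NC(=O)CCCCCCNC(=O)C(O)(O)C(F)(F)F)cc1` gives 12100 nM.
Compound 3 `O=C(CCCCNC(=O)C(O)(O)C(F)(F)F)Nc1ccccc1` gives 20300 nM.

Compound 1 stands with the highest number of the three. Compound 3 sits within the scatter of compound 1, so no order between the two can be read; compound 2 lies beyond the scatter with the lower number. No two of these compounds differ in a single place, so no measured step is available.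

Compound 4 `O=C(CCCCCCNC(=O)C(O)(O)C(F)(F)F)Nc1ncc(-c2ccccc2)s1` has not yet been measured. Compared with compound 1 the change is hydrogen in place of phenyl on an aromatic carbon. With no measured step of this kind in the series, no shift beyond the scatter is expected in this assay in either direction. The step implied by this estimate is a 1.2-fold higher number from compound 1 to compound 4 (0.07 log units; within the scatter). Compound 4 is estimated at 35000 nM, with a range from 12000 nM to 100000 nM.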

Compound 4, half-maximal inhibitory concentration: 2660 nM
Beside the measured number, compound 4's estimate is 13-fold (1.12 log units) above it; the measured number lies below the stated range.
By their numbers in this assay, from the lowest: compound 4; then compounds 2, 3 and 1 (each within the scatter of the next, the first and the last beyond it).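

In this assay, within the data shown here, the aromatic carbon next to the ring nitrogen is the one place so far where a single change has a measured effect: hydrogen in place of phenyl gives an 11-fold lower number from compound 1 to compound 4 (1.05 log units; beyond the scatter) with the rest of the structure unchanged. Phenyl at this position is therefore not required for inhibition in these cells. No measurement at hand bears on the reason for a step of this size.

As far as these compounds go, whether a small group such as methyl or a chlorine atom at this position behaves like hydrogen or like phenyl remains open. Also open, from the compounds shown here alone, is whether the phenyl group that stays on the ring contributes to the number of compound 4.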